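The compounds below may be only part of what the source reports. "The series", "measured", "known", "first", "only" and "open" are said of these compounds alone.

For the measured compounds named here, compound 2 `CCCCCCCCCCCCCCCOC(=O)CCC(=O)N1CCN(CCCOc2cc3c(Nc4ccc(F)c(Cl)c4)ncnc3cc2OC)CC1` gives 81.6% in a functional assay on A549 cells (Homo sapiens) for cytotoxicity, read by MTT assay, with a stated time of 24 h, tested at 60 uM (on this read-out higher numbers stand for a weaker effect at the one concentration tested and lower numbers for a stronger effect), the higher of the two numbers measured so far; compound 1 `CCCCCCCCCCCCCOC(=O)CCC(=O)N1CCN(CCCOc2cc3c(Nc4ccc(F)c(Cl)c4)ncnc3cc2OC)CC1` gives 20.6%. Compound 3 `CCCCCCCCCCCCCCCCOC(=O)CCC(=O)N1CCN(CCCOc2cc3c(Nc4ccc(F)c(Cl)c4)ncnc3cc2OC)CC1` differs from compound 2 by methyl in place of hydrogen on a saturated chain carbon, ten or more bonds along the chain from an oxygen next to a carbonyl group. Going by the values given here, the only measured step that bears on this change is a number 61 percentage points higher from compound 1 to compound 2 (beyond the scatter), a large upward move for a longer chain. A smaller extension is expected to move in the same direction, though with little room left on the scale, so the expected step is a number 6.4 percentage points higher from compound 2 to compound 3 (within the scatter). Compound 3 is therefore estimated at 88%, within 62% to 100%.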

Compound 3, a percentage reported as activity, at one concentration (the size of the read-out at that concentration, not a potency): 80%
The estimate for compound 3 lay 8 percentage points above the measured number; the measured number falls inside the stated range.
By their numbers in this assay, from the lowest: compound 1; then compounds 3 and 2 (each within the scatter of the next).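

On the saturated chain, methyl in place of hydrogen at this far position gives a number 1.6 percentage points lower from compound 2 to compound 3 (within the scatter) in this assay and so does not continue the large earlier rise. The full extension still gives a number 59.4 percentage points higher from compound 1 to compound 3 (beyond the scatter) and thus places the large gap of these three compounds between the shortest chain and the two longer ones. Nothing shown gives a reason for this. Still open, going by these compounds, is how a shorter chain, or a carboxylic acid in place of the long chain's ester, would read in this assay at this concentration.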